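The source may hold more compounds than are shown below. What is called first, only, known or untested is meant among the compounds shown, and "the series" means these compounds.

Compound 1, `CC(C)c1ccc(O)c(CC[C@@H]2[C@@](C)(O)CCC[C@@]2(C)C(=O)O)c1`: in a functional assay on QGY-7703 cells (Homo sapiens) for antiproliferative activity (a lower number here means a stronger inhibitor, a higher number a weaker inhibitor), compound 1 gives > 25 ug/mL, which is a limit of the assay rather than a number.
Compound 2, `C=C[C@@](C)(O)CC[C@H]1C(=C)CC[C@H]2C(C)(C)CCC[C@]12C`: in this assay compound 2 gives > 25 ug/mL, again a limit rather than a measured number.

Compound 2 therefore has no exact figure to stand on; its result is only a limit. Among the measured compounds shown here, the one other value shown is a limit as well, so both measured compounds sit at the limit of > 25 ug/mL in this assay, at which 2 of the 2 values shown sit, and neither can be ranked against the other. For the measured compounds named here, no step between two measured compounds is available to guide what a change to compound 2 should do.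

Compound 3, `C=C[C@@](C)(O)CC[C@H]1C(=C)CC[C@H]2[C@](C)(COC(=O)CCC(=O)OC)CCC[C@]12C`, differs from compound 2 in one place: ((2-(methoxycarbonyl)ethyl)carbonyl)oxy in place of hydrogen on a saturated chain carbon bound to a saturated ring carbon. The core that the two share is otherwise kept. Going by the values given here, with no measured step in hand, the expectation for compound 3 rests only on the limit of compound 2, and the most likely outcome is that compound 3 is also found at the limit in this assay. The expected step is a step that the limit leaves unreadable from compound 2 to compound 3, meaning no change beyond the usual scatter. For compound 3 the estimate in this assay is 30 ug/mL, with a range from 10 ug/mL to 100 ug/mL.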

Compound 3, half-maximal inhibitory concentration: > 25 ug/mL
Compound 3 gave a limit, no number (the forecaster's own chance of this, stated with the estimate: 70%); the middle value is on the limit's open side.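

Compound 2 and compound 3 both end at a limit rather than a number in this assay, so no step can be read from one to the other: the limit of > 25 ug/mL in this assay, at which 3 of the 3 values shown sit.

The compounds shown leave open whether the ((2-(methoxycarbonyl)ethyl)carbonyl)oxy group changes anything in this assay, and what kind of compound would give an actual number there.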